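The source may hold more compounds than are shown below. What is called first, only, known or untested is meant among the compounds shown, and "the series" means these compounds.

Measured in a functional assay on U-266 cells (Homo sapiens) for inhibition, read by MTT assay, with a stated time of 72 h; on this read-out higher numbers stand for weaker inhibition and lower numbers for stronger inhibition:
- compound 1 `CC1(C)CCC(CN2CCN(c3ccc(C(=O)NS(=O)(=O)c4ccc(NCCCCCC(=O)NO)c([N+](=O)[O-])c4)c(Oc4cnc5[nH]ccc5c4)c3)CC2)=C(c2ccc(Cl)cc2)C1`: 27100 nM
- compound 2 `CC1(C)CCC(CN2CCN(c3ccc(C(=O)NS(=O)(=O)c4ccc(NCCCCCCC(=O)NO)c([N+](=O)[O-])c4)c(Oc4cnc5[nH]ccc5c4)c3)CC2)=C(c2ccc(Cl)cc2)C1`: 9800 nM

Compound 2 has the lower of the two numbers, at 9800 nM. Compound 3 `CC1(C)CCC(CN2CCN(c3ccc(C(=O)NS(=O)(=O)c4ccc(NCCCCCCCC(=O)NO)c([N+](=O)[O-])c4)c(Oc4cnc5[nH]ccc5c4)c3)CC2)=C(c2ccc(Cl)cc2)C1` is the next member: (hydroxycarbamoyl)methyl in place of hydroxycarbamoyl on a saturated chain carbon, six bonds along the chain from a nitrogen on an aromatic ring. In words, (hydroxycarbamoyl)methyl stands in place of hydroxycarbamoyl on a saturated chain carbon, six bonds along the chain from a nitrogen on an aromatic ring. Among the compounds with values here, only one measured step bears on this, the same change made five bonds along the chain: a 2.8-fold lower number from compound 1 to compound 2 (0.44 log units; beyond the scatter). A single step sets no trend, so a further drop of similar or smaller size is expected, with little confidence. The expected step in this assay is a 2.0-fold lower number from compound 2 to compound 3 (0.29 log units; within the scatter). For compound 3 the estimate is 5000 nM, with an expected range of 1800 nM to 14000 nM.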

Compound 3, half-maximal inhibitory concentration: 8700 nM
For compound 3 the middle estimate is 1.7-fold (0.24 log units) below the measured one, within the range that was stated.
By their numbers in this assay, from the lowest: compounds 3 and 2 (each within the scatter of the next); then compound 1.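

In this assay, within the data shown here, one more chain carbon at this place no longer separates the compounds (a 1.1-fold lower number from compound 2 to compound 3 (0.05 log units; within the scatter)), unlike the same change made five bonds along the chain. Across both added carbons the difference remains modest (a 3.1-fold lower number from compound 1 to compound 3 (0.49 log units; beyond the scatter)), which places compound 2 and compound 3 together, apart from compound 1. No measurement available here explains this flattening. Still open, going by these compounds, is whether a longer chain stays at this level, and whether a carboxylic acid in place of the hydroxycarbamoyl end moves the number beyond the scatter.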